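Replacing the chlorophenyl on the cyclopropane with a difluorophenyl

This account rests on a few compounds, and the source may have more. Where it says the series, first, only, none or still open, it means among the compounds named here.

In a functional assay for agonist activity at G protein-coupled receptor 88 (Homo sapiens), read by HTRF and cAMP accumulation (a lower number here means that less compound is needed, a higher number that more compound is needed for the effect), compound 1 `CC[C@H](C)[C@@H](CN(C(=O)[C@@H]1C[C@H]1c1ccccc1)c1ccc(-c2ccccc2)cc1)NC(C)=O` gives 5.8 nM. Among the compounds with values here, compound 2 `CCC(CC)C(N)CCN(C(=O)[C@@H]1C[C@H]1c1ccccc1)c1ccc(-c2ccccc2)cc1` gives 2 nM, and the only single-point step among the measured compounds, a 2.9-fold lower number from compound 1 to compound 2 (0.46 log units; beyond the scatter), sits on the chain carbon bound to the amide-type nitrogen, not on the cyclopropane. Compound 3 `CC[C@H](C)[C@H](N)CN(C(=O)[C@@H]1C[C@H]1c1ccccc1Cl)c1ccc(-c2ccccc2)cc1` returns only a limit of the assay, > 25000 nM, so its true value is not known beyond that. That limit is the limit of > 25000 nM in this assay, at which 1 of the 3 values shown sits, the point at which one of the three values reported so far sits.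

Compound 4 `CC[C@H](C)[C@H](N)CN(C(=O)[C@@H]1C[C@H]1c1c(F)cccc1F)c1ccc(-c2ccccc2)cc1` differs from compound 3 in a single place: 2,6-difluorophenyl in place of 2-chlorophenyl on a saturated ring carbon. Within the data shown here, no measured step touches the aryl group on the cyclopropane, and the step from compound 1 to compound 2 concerns a different part of the molecule, so it offers no guidance on the direction or size of the change. Compound 3 gives only a limit, which makes the starting point itself uncertain. On this basis the expected step of a number no higher from compound 3 to compound 4 (the limit leaves the size open) is essentially none that could be seen, and it is estimated that compound 4 will again most likely fall outside the measurable window, with a central estimate of 25000 nM and a range of 4000 nM to 80000 nM.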

Compound 4, half-maximal effective concentration: 11000 nM
For compound 4 the middle estimate is 2.3-fold (0.36 log units) above the measured one; the measured number falls inside the stated range.
By their numbers in this assay, from the lowest: compound 2; then compound 1; then compound 4. At a limit, above all of these: compound 3.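

The aryl group on the cyclopropane turns out to be a place where one change moves the reading: with 2,6-difluorophenyl in place of 2-chlorophenyl on the saturated ring carbon, this assay shows an at least 2.2-fold lower number from compound 3 to compound 4 (0.35 log units; beyond the scatter). Compound 4 gives 11000 nM, a measured number, so this change brings the compound inside the range of the assay, whereas the earlier step concerned only the chain on the amide-type nitrogen. The value of compound 3 remains a limit and not a number, so the step gives only the smallest possible size of the change, and its true size stays unknown: the limit of > 25000 nM in this assay, at which 1 of the 4 values shown sits.

What the compounds shown leave open is whether the change in number follows the loss of the chlorine or the presence of a second fluorine, a question that 2-fluorophenyl or 2,6-dichlorophenyl on the same carbon would address. Within the data shown here, they also leave open how a plain phenyl on the cyclopropane would read alongside the free amine and 2-methylbutyl-type chain of compound 4, since the one step at this position covers only these two aryl groups.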